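Dimethoxy anilines on a shared core: adding a third methoxy

A few compounds are considered here, and "the series" means these few. Any claim that something is new, unique, unknown or untested is made for them only; others in the source may bear on it.

Of the compounds shown here, two have numbers so far. Compound 1, `COc1cc(Nc2nc(SCc3ccc(C(F)(F)F)cc3)nc3ccccc23)cc(OC)c1`, gives 8580 nM in a functional assay on MGC-803 cells (Homo sapiens) for cytotoxicity, read by MTT assay, with a stated time of 72 h; a lower number here means a stronger inhibitor, a higher number a weaker inhibitor. Among the measured compounds shown here, compound 2, `COc1ccc(Nc2nc(SCc3ccc(C(F)(F)F)cc3)nc3ccccc23)cc1OC`, gives 16300 nM in this assay, the higher of the two numbers; its only neighbour is compound 1, and the move a 1.9-fold higher number from compound 1 to compound 2 (0.28 log units; within the scatter) is the sole step in the set.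

Compound 3, `COc1cc(Nc2nc(SCc3ccc(C(F)(F)F)cc3)nc3ccccc23)cc(OC)c1OC`, has not been measured. Relative to compound 2 the change is methoxy in place of hydrogen on an aromatic carbon. For the measured compounds named here, no measured pair shows exactly this addition; the one step that bears on it at all is the repositioning of a methoxy group, a 1.9-fold higher number from compound 1 to compound 2 (0.28 log units; within the scatter), which stayed within the scatter. On that evidence a change in the count of methoxy groups on the same ring is expected to produce no step beyond the scatter in this assay, in either direction.

The number for compound 3 is therefore estimated near that of compound 2, with the step of a 1.1-fold lower number from compound 2 to compound 3 (0.04 log units; within the scatter) expected. Compound 3 is estimated at 15000 nM in this assay, within 5000 nM to 45000 nM.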

Compound 3, half-maximal inhibitory concentration: 8240 nM
The estimate for compound 3 lay 1.8-fold (0.26 log units) above the measured number; low and high end bracket the measured number.
By their numbers in this assay, from the lowest: compounds 3, 1 and 2 (each within the scatter of the next).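

The count of methoxy groups on the aniline ring can now be read directly, not only their arrangement. A methoxy in place of hydrogen on the aromatic carbon that is ortho to a methoxy group and meta to a large group gives a 2.0-fold lower number from compound 2 to compound 3 (0.30 log units; within the scatter) in this assay, and the step from the other dimethoxy aniline gives a 1.0-fold lower number from compound 1 to compound 3 (0.02 log units; within the scatter). Compound 3 is thus reached from two different dimethoxy patterns by one added methoxy, and neither step lies beyond the scatter, so this addition does not separate the trimethoxy aniline from either parent in this assay; nothing on hand accounts for this result.

From the compounds shown here alone, whether a group other than methoxy on this carbon, such as an amine, a carboxylic acid or a longer ethoxy chain, would give a step beyond the scatter remains open. Going by these compounds, all three compounds also share the trifluoromethyl-bearing side of the core, so how these methoxy steps read with another group there is equally open.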